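The source may report more compounds than this note shows. Statements on the series, on what has been measured and on what is new or still open speak of the compounds shown alone.

Compound 2 `O=C(CCCCCCCc1cn(-c2ccccc2CO)nn1)NCc1cccnc1` gives 96% in a functional assay on SH-SY5Y cells (Homo sapiens) for cytotoxicity, read by MTT assay, with a stated time of 48 h, tested at 10 uM (on this read-out higher numbers stand for a weaker effect at the one concentration tested and lower numbers for a stronger effect), the higher of the two numbers measured there. Compound 1 `O=C(CCCCCCCCc1cn(-c2cnc3ccccc3c2)nn1)NCc1cccnc1` gives 29% in this assay, a gap to compound 2 well beyond the scatter. Compound 3 `O=C(CCCCCCCc1cn(-c2ccccc2Cc2ccccc2)nn1)NCc1cccnc1` differs from compound 2 in a single place: phenyl in place of hydroxy on a saturated chain carbon bound to an aromatic carbon. Going by the values given here, no measured pair shows this change, so its effect can only be estimated. A modest fall in the number, of a size near the edge of the scatter, is expected. The estimate for compound 3 is 80%, within 45% to 100%. The expected step is a number 16 percentage points lower from compound 2 to compound 3 (beyond the scatter).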

Compound 3, a percentage reported as activity, at one concentration (the size of the read-out at that concentration, not a potency): 94%
Compound 3: the middle estimate sits 14 percentage points below what was measured, and the stated range covers the measured number.
By their numbers in this assay, from the lowest: compound 1; then compounds 3 and 2 (each within the scatter of the next).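

In this assay, phenyl in place of hydroxy on a saturated chain carbon bound to an aromatic carbon gives a number 2 percentage points lower from compound 2 to compound 3 (within the scatter) and so leaves the read-out where it stood. This place therefore takes the larger group, with its six-membered aromatic ring and without the hydrogen-bond donor and acceptor of hydroxy, and no shift beyond the scatter follows. Nothing measured here bears on the reason for this result. As far as these compounds go, whether an amine or a carboxylic acid in this place would also leave the number unmoved stays open. So does whether hydroxymethyl to benzyl would do the same on the core of compound 1.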